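One Group Exchanged on Compound 3

The source may report more compounds than this note shows. Statements on the series, on what has been measured and on what is new or still open speak of the compounds shown alone.

In an ADME assay on HEK293 cells (Homo sapiens) for cytotoxicity (a lower number here means a stronger inhibitor, a higher number a weaker inhibitor), compound 1 (`COC(=O)c1c(C)cc(OC(=O)c2c(C)cc(O)c(/C=N/NC(=O)Cc3ccccc3)c2O)c(C)c1O`) gives > 100000 nM, which is a limit of the assay and not a number. Compound 2 (`COC(=O)c1c(C)cc(OC(=O)c2c(C)cc(O)c(/C=N/NC(=O)COc3ccc(C)cc3)c2O)c(C)c1O`) gives > 100000 nM, again a limit. Among the measured compounds shown here, compound 3 (`COC(=O)c1c(C)cc(OC(=O)c2c(C)cc(O)c(/C=N/NC(=O)COc3ccc4ccccc4c3)c2O)c(C)c1O`) gives 52700 nM, the only true number among the three.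

Compound 4 (`COC(=O)c1c(C)cc(OC(=O)c2c(C)cc(O)c(/C=N/NC(=O)CSc3nc4ccccc4s3)c2O)c(C)c1O`) keeps the shared core and changes one group: (1,3-benzothiazol-2-yl)sulfanyl in place of (naphthalen-2-yl)oxy on a saturated chain carbon bound to a carbonyl carbon. Thus (1,3-benzothiazol-2-yl)sulfanyl stands in place of (naphthalen-2-yl)oxy on a saturated chain carbon bound to a carbonyl carbon.

For the measured compounds named here, two measured steps bear on this change, both made at the same place: an at least 1.8-fold lower number from compound 1 to compound 3 (0.27 log units; that floor lies within the scatter), and an at least 1.8-fold lower number from compound 2 to compound 3 (0.27 log units; that floor lies within the scatter). Both give only a floor, so neither provides a firm size for a step at this place, and no step beyond the scatter is expected here. The expected change is a 1.0-fold higher number from compound 3 to compound 4 (0.02 log units; within the scatter). Compound 4 is estimated at 55000 nM, with an expected range of 22000 nM to 100000 nM.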

Compound 4, half-maximal inhibitory concentration: 70100 nM
Compound 4: middle estimate off by 1.3-fold (0.11 log units), on the low side, and the stated range covers the measured number.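

In this assay, among the compounds shown here, the exchange of (naphthalen-2-yl)oxy for (1,3-benzothiazol-2-yl)sulfanyl on a saturated chain carbon bound to a carbonyl carbon gives the first step at this place with both ends measured as true numbers: a 1.3-fold higher number from compound 3 to compound 4 (0.12 log units; within the scatter). Compound 3 and compound 4 therefore cannot be told apart here, although the entering group brings hetero atoms that the leaving group lacks. Toward the other two compounds only floors can be read, an at least 1.4-fold lower number from compound 2 to compound 4 (0.15 log units; that floor lies within the scatter) and an at least 1.4-fold lower number from compound 1 to compound 4 (0.15 log units; that floor lies within the scatter), because both steps start from a limit of the assay: the limit of > 100000 nM in this assay, at which 2 of the 4 values shown sit.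

The exchange alters the linking atom and the ring system together, so (naphthalen-2-yl)sulfanyl would be needed to separate the two. Going by these compounds, how this assay responds to an amine or a carboxylic acid at this place also remains open.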